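Thioether series: halogen returns, chain lengthened

This account rests on a few compounds, and the source may have more. Where it says the series, first, only, none or still open, it means among the compounds named here.

Going by the values given here, compound 2 `COc1cccc(CCSc2nc3c(c(=O)n(C)c(=O)n3C)n2C)c1` stands highest of the two numbers so far: in an assay on microsomes for inhibition of Amine oxidase [flavin-containing] A (Homo sapiens), read by fluorescence and spectrophotometry, with a stated time of 20 min (a lower number here means a stronger inhibitor, a higher number a weaker inhibitor), compound 2 gives 48100 nM, whereas compound 1 `Cn1c(=O)c2c(nc(SCCc3cccc(Br)c3)n2C)n(C)c1=O` gives 5700 nM. Among the compounds with values here, the only measured step, an 8.4-fold higher number from compound 1 to compound 2 (0.93 log units; beyond the scatter), put methoxy in place of bromo on an aromatic carbon. Compound 3 `Cn1c(=O)c2c(nc(SCCCc3cccc(Cl)c3)n2C)n(C)c1=O` is not yet measured; against compound 2 it shows (3-chlorobenzyl in place of 3-methoxyphenyl on a saturated chain carbon, two bonds along the chain from a sulfur). Within the data shown here, the measured step bears on this only in part: a halogen comes back where methoxy stood, and the one step recorded, an 8.4-fold higher number from compound 1 to compound 2 (0.93 log units; beyond the scatter), ran the other way when the halogen left. Among the measured compounds shown here, the chain is also one carbon longer, and no measured pair speaks to that. A lower number than compound 2 is therefore expected, roughly back toward compound 1, with a wide range. Compound 3 is estimated at 10000 nM, between 3000 nM and 40000 nM, an expected step of a 4.8-fold lower number from compound 2 to compound 3 (0.68 log units; beyond the scatter).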

Compound 3, half-maximal inhibitory concentration: 3530 nM
Compound 3: the middle estimate sits 2.8-fold (0.45 log units) above what was measured; the measured number falls inside the stated range.
By their numbers in this assay, from the lowest: compounds 3 and 1 (each within the scatter of the next); then compound 2.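

In this assay, a 14-fold lower number from compound 2 to compound 3 (1.13 log units; beyond the scatter) accompanies 3-chlorobenzyl in place of 3-methoxyphenyl on a saturated chain carbon, two bonds along the chain from a sulfur, which leaves compound 2 as the weakest inhibitor of the three and shows that this position can recover the loss seen with methoxy. With a 1.6-fold lower number from compound 1 to compound 3 (0.21 log units; within the scatter) for 3-chlorobenzyl in place of 3-bromophenyl at the same place, compound 1 and compound 3 are not separated, so the chlorine-bearing group with its longer chain and the bromine-bearing group read alike here. No measurement accompanies these steps to account for them.

The step from compound 2 to compound 3 changes the ring substituent and the chain together, and the share of each stays unresolved. Also open, from the compounds shown here alone, is whether a still longer chain, or a nitrile or an amine on the ring, would hold this level.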